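The compounds below may be only part of what the source reports. "The series", "measured", "known", "first", "only" and "open" are said of these compounds alone.

Measured so far in an assay on HEK293 cells for inhibition of Steryl-sulfatase (Homo sapiens), tested at 0.1 uM; a lower number here means a weaker effect, a higher number a stronger effect of the compound at the concentration tested:
compound 1, `NS(=O)(=O)Oc1ccc2c(c1)CN(C(=O)c1ccc(N(Cc3ccccc3)Cc3ccco3)cc1)CC2`, gives 90.8%
compound 2, `CN(CCCN1CCCCC1)c1cccc(C(=O)N2CCc3ccc(OS(N)(=O)=O)cc3C2)c1`, gives 24.1%
compound 3, `NS(=O)(=O)Oc1ccc2c(c1)CN(C(=O)c1cccc(N3CCC(Cc4ccccc4)CC3)c1)CC2`, gives 1.4%

Of the three numbers, compound 2 holds the second highest. Its nearest neighbour is compound 3, whose value lies below it by a gap that is beyond the scatter; the furthest is compound 1, whose value lies above it by a much larger gap, also beyond the scatter. No pair of these compounds differs in only one place, so no single step has been measured in this assay and there is no directly comparable precedent for the change considered next.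

The next compound, compound 4, `CN(CCN1CCCCC1)c1cccc(C(=O)N2CCc3ccc(OS(N)(=O)=O)cc3C2)c1`, is reached from compound 2 by the change (piperidin-1-yl in place of (piperidin-1-yl)methyl on a saturated chain carbon, two bonds along the chain from a nitrogen on an aromatic ring). Expressed one bond further out, the same difference reads methyl(3-(piperidin-1-yl)propyl)amino to methyl(2-(piperidin-1-yl)ethyl)amino. Nothing in the three measured compounds isolates this one change, so the expectation rests on compound 2 alone: the step from compound 2 to compound 4 is expected to be small and is estimated as a number 4.1 percentage points lower from compound 2 to compound 4 (within the scatter), likely not beyond the scatter. For compound 4 in this assay a value around 20% is estimated, within a range from 5% to 45%.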

Compound 4, a percentage reported as inhibition, at one concentration (the size of the read-out at that concentration, not a potency): 24.5%
Estimate against measurement, compound 4: 4.5 percentage points below, within the range that was stated.
By their numbers in this assay, from the lowest: compound 3; then compounds 2 and 4 (each within the scatter of the next); then compound 1.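

In this assay, going by these compounds alone, the chain between the nitrogen on the aromatic ring and the piperidine was tested for the first time, with methyl(2-(piperidin-1-yl)ethyl)amino standing for methyl(3-(piperidin-1-yl)propyl)amino, and the result is a number 0.4 percentage points higher from compound 2 to compound 4 (within the scatter). At this place, on a saturated chain carbon, two bonds along the chain from a nitrogen on an aromatic ring, piperidin-1-yl in place of (piperidin-1-yl)methyl therefore gives two compounds that this read-out cannot tell apart, so for this pair the length of the chain does not set the value at the concentration tested. No supporting measurement is available that would account for this result.

From the compounds shown here alone, whether a longer chain such as 4-(piperidin-1-yl)butyl, or another terminal amine such as morpholine or dimethylamino on the 2-(piperidin-1-yl)ethyl chain position, would separate from compound 4 in this assay remains open. Also open, going by these compounds, is whether compound 2 and compound 4 would differ in potency, since a percentage at a single concentration does not give one.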